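A few compounds are considered here, and "the series" means these few. Any claim that something is new, unique, unknown or untested is made for them only; others in the source may bear on it.

Compound 1 `CCOC(=O)c1ccc(Nc2ccnc(SCC(=O)c3ccc([N+](=O)[O-])cc3)n2)cc1` stands at the top of the three numbers gathered so far. In a functional assay on A498 cells (Homo sapiens) for inhibition, read by sulforhodamine B assay, with a stated time of 48 h, tested at 10 uM (a higher number here means more inhibition of growth at the concentration tested, a lower number less inhibition of growth), compound 1 gives 61%. Compound 2 `COc1ccc(C(=O)CSc2nccc(Nc3cccc(C(C)=O)c3)n2)cc1` gives in this assay a reading of 22%, and compound 3 `CC(=O)c1ccc(Nc2ccnc(SCC(=O)c3ccc(Br)cc3)n2)cc1` gives in this assay a reading of 19%; both of these lie well below compound 1, beyond the usual scatter, while compound 2 and compound 3 sit within the scatter of each other.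

Compound 4 `CCOC(=O)c1ccc(Nc2ccnc(SCC(=O)c3ccc(C#N)cc3)n2)cc1` has not yet been measured in this assay. It differs from compound 1 in one place: cyano in place of nitro on an aromatic carbon. Among the compounds with values here, no pair of measured compounds isolates this change, so its effect cannot be read from the data in hand. The size of the step from compound 1 to compound 4 in this assay is therefore uncertain; a modest loss or no change beyond the scatter seems the most reasonable expectation, and the expected step is a number 11 percentage points lower from compound 1 to compound 4 (beyond the scatter). On that basis compound 4 is estimated to reach 50% in this assay, with a range from 30% to 70%.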

Compound 4, percent growth inhibition at one concentration: 50%
Compound 4: middle estimate and measured number agree at the digits printed, within the range that was stated.
By their numbers in this assay, from the lowest: compounds 3 and 2 (each within the scatter of the next); then compound 4; then compound 1.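

In this assay, within the data shown here, this is the first step that isolates a single place, the group para to a large group on the aromatic ring, and going from 4-nitrophenyl to 4-cyanophenyl gives a modest loss beyond the scatter: a number 11 percentage points lower from compound 1 to compound 4 (beyond the scatter). Nitro is therefore not strictly required at this position, as much of the growth inhibition remains with cyano in its place, although the two groups do not read the same. No measured evidence here accounts for the size of this step.

From the compounds shown here alone, whether an amine or a carboxylic acid at the same position would retain or lose the reading remains open. Going by these compounds, it is also open whether this step would carry over to a compound bearing an acetyl group in place of the ethyl ester.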